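The compounds below may be only part of what the source reports. "The series", "measured", "known", "first", "only" and "open" are said of these compounds alone.

Measured in an assay on CHO cells for displacement of a labelled ligand from Orexin/Hypocretin receptor type 1 variant I408V (Homo sapiens), read by scintillation counting; a lower number here means a stronger inhibitor, a higher number a weaker inhibitor:
compound 1 `COc1ccc(CNC(=O)c2cc(-c3cncc(C)c3)ncc2-c2cncc(F)c2)nc1OC`: 17000 nM
compound 2 `COc1ccc(CNC(=O)c2cc(-c3cncc(C)c3)ncc2-c2cnccn2)nc1OC`: 31000 nM
compound 3 `COc1ccc(CNC(=O)c2nc(-c3cncc(C)c3)ncc2-c2ccccc2)nc1OC`: 23000 nM

Compound 2 gives the largest number of the three, yet its gap to compound 3 and its gap to compound 1 both lie within the scatter, so the three compounds sit on one level in this assay; compound 3 also differs from compound 2 in more than one place, so its value is only a reference point, not a step.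

Compound 4 `COc1ccc(CNC(=O)c2cc(-c3cncc(C)c3)ncc2-c2cnn(C)c2)nc1OC` is not yet measured. It differs from compound 2 by 1-methyl-1H-pyrazol-4-yl in place of pyrazin-2-yl on an aromatic carbon. Going by the values given here, the one step that bears on this change is a 1.8-fold higher number from compound 1 to compound 2 (0.26 log units; within the scatter), a swap of one six-membered ring with two hetero atoms for another at the same place, which stayed within the scatter. The change to compound 4 again exchanges a ring of six heavy atoms with two nitrogens for one of the same count, here a five-membered ring, at the same place. Among the compounds with values here, no measured step separates these rings, so no movement beyond the scatter is expected for compound 4 in this assay.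

The estimated step is a 1.2-fold lower number from compound 2 to compound 4 (0.09 log units; within the scatter). Compound 4 is therefore expected to give about 25000 nM, with a range from 9000 nM to 70000 nM.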

Compound 4, inhibition constant: 930 nM
For compound 4 the middle estimate is 27-fold (1.43 log units) above the measured one; the whole stated range lies above it.
By their numbers in this assay, from the lowest: compound 4; then compounds 1, 3 and 2 (each within the scatter of the next).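

In this assay, the position ortho to a large group and para to a 5-methylpyridin-3-yl group proves sensitive to the ring it carries: 1-methyl-1H-pyrazol-4-yl in place of pyrazin-2-yl gives a large step (a 33-fold lower number from compound 2 to compound 4 (1.52 log units; beyond the scatter)), and in place of 5-fluoropyridin-3-yl gives another (an 18-fold lower number from compound 1 to compound 4 (1.26 log units; beyond the scatter)), both beyond the scatter, while the exchange between the two six-membered rings stayed within it (a 1.8-fold higher number from compound 1 to compound 2 (0.26 log units; within the scatter)). The flat level of compounds 1, 2 and 3 therefore did not show how far this position can move the binding value. Pyrazin-2-yl and 1-methyl-1H-pyrazol-4-yl match in heavy atoms, hetero atoms, hydrogen-bond donors and acceptors and net charge, so none of these counts separates them, and no measurement available here accounts for the difference.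

A 1H-pyrazol-4-yl group without the methyl, or 1-ethyl-1H-pyrazol-4-yl, would separate the contribution of the ring from that of its substituent. Also open, on these data alone, is whether a five-membered aromatic ring alone is enough, which a thiazol-5-yl or an imidazol-4-yl group at this place would test.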